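The compounds below may be only part of what the source reports. "The series", "measured", "known", "first", "only" and "open" are said of these compounds alone.

Measured compounds and values in a functional assay on the whole organism (strain Wistar) for inhibition, with Rattus norvegicus as the target, with stated times of 30 min and 3 h, at a dose of 20 mg/kg by the oral route; on this read-out lower numbers stand for less inhibition and higher numbers for more inhibition at the one dose given (going by the name of the read-out):

Compound 1, `Cc1ccc(C(=O)CCc2nnc(-c3ccccc3Cl)o2)cc1`, gives 57.3%.
Compound 2, `O=C(CCc1nnc(COc2ccc3ccccc3c2)o1)c1ccccc1`, gives 51%.

Compound 2 stands lowest of the two numbers, but its nearest neighbour, compound 1, lies higher by an amount that falls within the usual scatter of this assay, so the two cannot be ranked against each other. For the measured compounds named here, no step between measured compounds that differ in one place is available, so nothing is known directly about how a single change on the shared core moves the read-out.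

Compound 3, `Cc1ccc(C(=O)CCc2nnc(COc3ccc4ccccc4c3)o2)cc1`, is not yet measured. It differs from compound 2 by methyl in place of hydrogen on an aromatic carbon. Going by the values given here, the only other example carrying a methyl on a six-membered aromatic ring of carbon only, compound 1, sits within the scatter of compound 2, and its other side of the core is different, so it gives no clean guide.

The step from compound 2 to compound 3 in this assay is expected to be small, with no clear direction beyond the scatter, as a number 3 percentage points higher from compound 2 to compound 3 (within the scatter). For compound 3 the estimate is 54%, expected to fall between 40% and 68%.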

Compound 3, a percentage reported as inhibition, in the whole organism at one dose (the size of the read-out at that dose, not a potency): 49.4%
Estimate against measurement, compound 3: 4.6 percentage points above; measured number inside the range.
By their numbers in this assay, from the lowest: compounds 3, 2 and 1 (each within the scatter of the next).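

In this assay, for the compounds shown here, the change from phenyl to 4-methylphenyl on the benzoyl end gives the first clean reading at this position: a number 1.6 percentage points lower from compound 2 to compound 3 (within the scatter). With the rest of compound 2 held fixed, methyl in place of hydrogen on this aromatic carbon, para to a large group, leaves the inhibition at this one dose indistinguishable from that of compound 2, something compound 1 could not show, since the other side of its core also differs. No measurement at hand speaks to the reason for this outcome.

As far as these compounds go, whether this position responds to anything other than methyl remains open: a carboxylic acid, an amine or a longer chain such as butyl on the same aromatic carbon would show whether the read-out can move at all from this site. Also open is the contribution of the other side of the core, since compound 1 and compound 3 differ there in more than one place and no single step among the compounds shown isolates that part of the structure.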